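The source may hold more compounds than are shown below. What is called first, only, known or untested is meant among the compounds shown, and "the series" means these compounds.

Measured compounds:
- compound 1, `COc1ccc2c(=O)c(/C=C/C(=O)Nc3ccc(C)cc3)coc2c1`, in a functional assay on A549 cells (Homo sapiens) for inhibition, read by MTT assay, with a stated time of 48 h (on this read-out lower numbers stand for stronger inhibition and higher numbers for weaker inhibition), gives 17500 nM
- compound 2, `COc1ccc2c(=O)c(/C=C/C(=O)NCc3cccc(F)c3)coc2c1`, gives 26900 nM
- compound 3, `COc1ccc2c(=O)c(/C=C/C(=O)Nc3ccccc3)coc2c1`, gives 51000 nM

Compound 1 stands at the lowest of the three numbers, but only its gap to compound 3 is clearly beyond the scatter; compound 2 sits close to it. The new compound, compound 4, `COc1cccc(NC(=O)/C=C/c2coc3cc(OC)ccc3c2=O)c1`, differs from compound 1 in one place: 3-methoxyphenyl in place of 4-methylphenyl on an amide-type nitrogen.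

Among the measured compounds shown here, two measured steps bear on this change. The step from compound 1 to compound 3 takes away the same methyl group, and there the number rose: a 2.9-fold higher number from compound 1 to compound 3 (0.46 log units; beyond the scatter). The step from compound 1 to compound 2 changes the whole group on the amide-type nitrogen, and there the number barely moved: a 1.5-fold higher number from compound 1 to compound 2 (0.19 log units; within the scatter). The step from compound 2 to compound 3 was also within the scatter: a 1.9-fold higher number from compound 2 to compound 3 (0.28 log units; within the scatter). For the measured compounds named here, nothing among the measured compounds shows what a methoxy group on that ring does, so compound 4 is expected to land somewhere between compound 1 and compound 3, most likely a modest step toward a higher number: a 1.7-fold higher number from compound 1 to compound 4 (0.23 log units; within the scatter). The estimate for compound 4 is 30000 nM, with a range from 12000 nM to 80000 nM.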

Compound 4, half-maximal inhibitory concentration: 12800 nM
Compound 4: middle estimate off by 2.3-fold (0.37 log units), on the high side, within the range that was stated.
By their numbers in this assay, from the lowest: compounds 4, 1, 2 and 3 (each within the scatter of the next, the first and the last beyond it).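

In this assay, methoxy in place of hydrogen on an aromatic carbon gives a 4.0-fold lower number from compound 3 to compound 4 (0.60 log units; beyond the scatter), a modest step beyond the scatter, so a substituent on this phenyl ring need not be methyl for the number to sit clearly under that of the bare phenyl. Exchanging 4-methylphenyl for 3-methoxyphenyl gives a 1.4-fold lower number from compound 1 to compound 4 (0.14 log units; within the scatter), which lies within the scatter, so these two substituted rings cannot be told apart here, whereas exchanging 3-fluorobenzyl for 3-methoxyphenyl gives a 2.1-fold lower number from compound 2 to compound 4 (0.32 log units; beyond the scatter), a modest step just beyond the scatter. Nothing among the available data explains any of these steps.

Because methyl and methoxy also sit at different places on the ring, the compounds shown cannot separate the effect of the group from the effect of its place, and a methoxy group at another ring carbon would be needed to tell these apart. On these data alone, it also remains open how this position would respond to quite different groups, such as an amine or a carboxylic acid on the ring, or a longer chain on the amide-type nitrogen.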